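The source may hold more compounds than are shown below. What is called first, only, known or untested is meant among the compounds shown, and "the series" means these compounds.

Compound 1 `Cc1c(Cc2ccc(F)cc2)c(=O)oc2cc(OCCOc3no[n+]([O-])c3S(=O)(=O)c3ccccc3)ccc12` is the starting point of this comparison. Going by the values given here, in a physicochemical assay for solubility, read by HPLC, in phosphate buffer, with a stated time of 24 h (a higher number here means a more soluble compound, a lower number a less soluble compound), compound 1 gives 0.01 ug/mL, the lowest of the two numbers measured so far. Compound 2 `Cc1c(CCC(=O)Nc2ccc(F)cc2)c(=O)oc2cc(OCCOc3no[n+]([O-])c3S(=O)(=O)c3ccccc3)ccc12` differs from compound 1 in a single place, and in this assay compound 2 gives 7.2 ug/mL; that one change brought a 720-fold higher number from compound 1 to compound 2 (2.86 log units; beyond the scatter). Compound 3 `Cc1c(CCC(=O)N2CCOCC2)c(=O)oc2cc(OCCOc3no[n+]([O-])c3S(=O)(=O)c3ccccc3)ccc12` has not yet been measured. It differs from compound 1 as follows: ((morpholin-4-yl)carbonyl)methyl in place of 4-fluorophenyl on a saturated chain carbon bound to an aromatic carbon. Among the compounds with values here, the one measured step that bears on this change is the step from compound 1 to compound 2, in which ((4-fluorophenyl)carbamoyl)methyl likewise replaced 4-fluorophenyl on the same saturated chain carbon bound to an aromatic carbon, and the number rose by a large amount. Because that measured step came to a 720-fold higher number from compound 1 to compound 2 (2.86 log units; beyond the scatter), a large rise in this assay is expected for compound 3 as well, of roughly a 2500-fold higher number from compound 1 to compound 3 (3.40 log units; beyond the scatter). Compound 3 is therefore estimated to reach 25 ug/mL, with a likely range from 4 ug/mL to 150 ug/mL, though only the measurement can show how far the new group actually carries it.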

Compound 3, solubility: 2 ug/mL
Compound 3: the middle estimate sits 13-fold (1.10 log units) above what was measured; measured number below the stated range.
By their numbers in this assay, from the lowest: compound 1; then compound 3; then compound 2.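

In this assay there is a 200-fold higher number from compound 1 to compound 3 (2.30 log units; beyond the scatter) when ((morpholin-4-yl)carbonyl)methyl takes the place of 4-fluorophenyl on the saturated chain carbon bound to an aromatic carbon, so a large rise at this position is now seen with two different groups, and the 4-fluorophenyl ring that compound 2 still carries is not needed for it. Changing only the group on the carbonyl carbon, with morpholin-4-yl in place of (4-fluorophenyl)amino, gives a 3.6-fold lower number from compound 2 to compound 3 (0.56 log units; beyond the scatter) and this modest step is small beside the large rise that both compound 2 and compound 3 show over compound 1. No measurement is at hand that explains why these numbers move as they do.

The compounds shown leave open whether the rise depends on the carbonyl at all, a question that a plain propyl chain at this position could answer. They also leave open how far the number would move with a carboxylic acid at the end of the same chain, or with a piperazin-1-yl group on the carbonyl carbon in place of morpholin-4-yl.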